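A few compounds are considered here, and "the series" means these few. Any claim that something is new, unique, unknown or untested is made for them only; others in the source may bear on it.

Measured in a functional assay on M4E cells (Homo sapiens) for cytotoxicity, read by resazurin assay, with a stated time of 72 h; a lower number here means a stronger inhibitor, a higher number a weaker inhibitor:
Compound 1 `COc1cc(/C=C/C(=O)OCCCCOc2no[n+]([O-])c2S(=O)(=O)c2ccccc2)ccc1O`: 840 nM
Compound 2 `COc1cc(/C=C/C(=O)OCCCCCCO[N+](=O)[O-])ccc1O`: > 50000 nM (a limit)
Compound 3 `O=C(/C=C/c1ccc(OCCCCCO[N+](=O)[O-])c(O)c1)OCCCCCO[N+](=O)[O-]`: > 50000 nM (a limit)

Of the three, only compound 1 has a true number, 840 nM. Compound 2 has only a limit, > 50000 nM, and no number.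

Compound 4 `COc1cc(/C=C/C(=O)OCCCCCO[N+](=O)[O-])ccc1O` has not yet been measured. It differs from compound 2 at the end of the ester chain, with nitrooxy in place of (nitrooxy)methyl on a saturated chain carbon, five bonds along the chain from an oxygen next to a carbonyl group.

No step beyond the scatter is expected in this assay. This expectation rests on (the limit of > 50000 nM in this assay, at which 2 of the 3 values shown sit), reached by compound 2 and compound 3. The estimated change is a number no higher from compound 2 to compound 4 (the limit leaves the size open). For compound 4 the expected value is 50000 nM, with an estimated range of 25000 nM to 100000 nM.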

Compound 4, half-maximal inhibitory concentration: 21800 nM
For compound 4 the middle estimate is 2.3-fold (0.36 log units) above the measured one; the whole stated range lies above it.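

In this assay, nitrooxy in place of (nitrooxy)methyl on this saturated chain carbon gives an at least 2.2-fold lower number from compound 2 to compound 4 (0.36 log units; beyond the scatter), so the end of the ester chain does register in this read-out. Among the nitrooxy esters shown, compound 4 alone has a true number, 21800 nM. Going by these compounds, the size of the step stays open, because compound 2 is held at a limit: the limit of > 50000 nM in this assay, at which 2 of the 4 values shown sit.

On these data alone, whether a shorter 3-(nitrooxy)propyl chain would lower the number further remains open. So does whether a hydroxyl group at the chain end would give a similar value.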